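The source may report more compounds than this note shows. Statements on the series, on what has been measured and on what is new or still open speak of the compounds shown alone.

Measured so far:
Compound 1 `CCCc1nc(C(C)(C)O)c(C(=O)O)n1Cc1ccc(-c2ccccc2C(=O)O)cc1` gives 50% in a functional assay on the whole organism for inhibition, with Rattus norvegicus as the target, with a stated time of 1 h, at a dose of 1 mg/kg; a lower number here means less inhibition, a higher number more inhibition at the dose given (going by the name of the read-out).
Compound 2 `CCCc1nc(C(C)(C)O)c(C(=O)OCOC(=O)OC(C)C)n1Cc1ccc(-c2ccccc2C(=O)O)cc1` gives 71% in this assay.

Among the compounds with values here, compound 1 stands lowest of the two numbers; the only measured step, a number 21 percentage points higher from compound 1 to compound 2 (beyond the scatter), puts compound 2 above it. Compound 3 `CCCc1nc(C(C)(C)O)c(C(=O)OC2OC(=O)c3ccccc32)n1Cc1ccc(-c2ccccc2C(=O)O)cc1` differs from compound 1 by a group of 10 heavy atoms (8 carbon, 2 oxygen; one five-membered non-aromatic ring with 1 hetero atom, one six-membered aromatic ring of carbon only) in place of a hydrogen atom, on an oxygen next to a carbonyl group. The step from compound 1 to compound 2 bears on this: there, too, the hydrogen on that oxygen was replaced by a larger group, and inhibition rose by a number 21 percentage points higher from compound 1 to compound 2 (beyond the scatter). A rise of comparable size is therefore expected here, a number 18 percentage points higher from compound 1 to compound 3 (beyond the scatter). Compound 3 is estimated at 68%, likely between 52% and 82%.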

Compound 3, a percentage reported as inhibition, in the whole organism at one dose (the size of the read-out at that dose, not a potency): 73%
The estimate for compound 3 lay 5 percentage points below the measured number, within the range that was stated.
By their numbers in this assay, from the lowest: compound 1; then compounds 2 and 3 (each within the scatter of the next).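

In this assay, a second group on the oxygen next to a carbonyl group, this one with rings, also raises the number (a number 23 percentage points higher from compound 1 to compound 3 (beyond the scatter)). The rise is therefore not confined to the group without a ring in compound 2, and exchanging that group for the ring-bearing one makes no clear difference (a number 2 percentage points higher from compound 2 to compound 3 (within the scatter)). No measurement available here accounts for the rise. Still open, going by these compounds, is whether a plain methyl or ethyl group on that oxygen, or a chain carrying an amine, would give a similar number.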